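The source may report more compounds than this note shows. Statements on the series, on what has been measured and on what is new or still open speak of the compounds shown alone.

Measured in a functional assay on HepG2 cells (Homo sapiens) for inhibition, read by MTT assay, with a stated time of 48 h; on this read-out higher numbers stand for weaker inhibition and lower numbers for stronger inhibition:
Compound 1 `COc1ccc(C(=O)C=CNc2cc(-c3ccccc3)nn2-c2ccccc2)cc1` gives 2030 nM
Compound 2 `c1ccc(-c2ccnc3c2c(-c2ccccc2)nn3-c2ccccc2)cc1` gives 3210 nM

In this assay compound 2, at 3210 nM, lies within the usual scatter of compound 1, at 2030 nM, so the two numbers cannot be told apart. The next compound, compound 3 `Cc1ccc(-c2ccnc3c2c(-c2ccccc2)nn3-c2ccccc2)cc1`, keeps the core of compound 2 and changes one group, phenyl to 4-methylphenyl: methyl in place of hydrogen on an aromatic carbon. This puts methyl in place of hydrogen on an aromatic carbon. Within the data shown here, no measured pair shows what such a change does, so no step beyond the scatter is expected in this assay, in either direction. The estimated 1.1-fold lower number from compound 2 to compound 3 (0.03 log units; within the scatter) is accordingly small. For compound 3 the expected value is 3000 nM, with an estimated range from 1200 nM to 7500 nM.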

Compound 3, half-maximal inhibitory concentration: 10700 nM
Compound 3: the middle estimate sits 3.6-fold (0.55 log units) below what was measured; measured number above the stated range.
By their numbers in this assay, from the lowest: compounds 1 and 2 (each within the scatter of the next); then compound 3.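

In this assay, among these compounds, the change of phenyl to 4-methylphenyl gives the first step that can be read at this position, a 3.3-fold higher number from compound 2 to compound 3 (0.52 log units; beyond the scatter). A single methyl in place of hydrogen, on an aromatic carbon para to a large group, is thus enough to shift the number towards weaker inhibition by more than the scatter, so this position is not indifferent to that change. Nothing at hand gives a reason for this step.

From the compounds shown here alone, whether chlorine, an amine or a carboxylic acid at the same place would also raise the number, or whether a longer chain such as ethyl would raise it further, stays open. Going by these compounds, it is also open whether the same methyl would have a like effect on the other phenyl group of the shared core.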